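Amine change in two benzophenone-type amides: an expected step

The source may hold more compounds than are shown below. What is called first, only, known or untested is meant among the compounds shown, and "the series" means these compounds.

Measured compounds:
Compound 1, `COc1ccc(C(=O)c2ccc3c(c2)C=CC(C)(C)O3)c(NC(=O)CN)c1`: 310 nM
Compound 2, `COc1ccc(C(=O)c2ccc3c(c2)C=CC(C)(C)O3)c(NC(=O)CN(C)C)c1`: 1160 nM
Compound 3, `COc1ccc(C(=O)c2cc(OC)c(OC)c(OC)c2)c(NC(=O)CN(C)C)c1`: 590 nM

In a functional assay on A549 cells (Homo sapiens) for antiproliferative activity, read by MTT assay, with a stated time of 48 h (a lower number here means a stronger inhibitor, a higher number a weaker inhibitor), compound 1 gives 310 nM, while compound 2 gives 1160 nM. The change from compound 2 to compound 1 is amino in place of dimethylamino on a saturated chain carbon bound to a carbonyl carbon and it gave a 3.7-fold lower number from compound 2 to compound 1 (0.57 log units; beyond the scatter). Compound 3 gives 590 nM, a value that lies within the scatter of both compound 1 and compound 2. How the core of compound 3 differs from that of compound 2 is not broken down here.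

Compound 4, `COc1ccc(C(=O)c2cc(OC)c(OC)c(OC)c2)c(NC(=O)CN)c1`, is not yet measured. It differs from compound 3 by amino in place of dimethylamino on a saturated chain carbon bound to a carbonyl carbon, the same change that was made from compound 2 to compound 1 on the other core. Because a 3.7-fold lower number from compound 2 to compound 1 (0.57 log units; beyond the scatter) was a modest step beyond the scatter, the step from compound 3 to compound 4 is expected to be of similar size, a 3.7-fold lower number from compound 3 to compound 4 (0.57 log units; beyond the scatter). Compound 4 is therefore estimated at 160 nM, with a likely range from 70 nM to 400 nM.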

Compound 4, half-maximal inhibitory concentration: 220 nM
The estimate for compound 4 lay 1.4-fold (0.14 log units) below the measured number, within the range that was stated.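

In this assay, amino in place of dimethylamino on a saturated chain carbon bound to a carbonyl carbon gave a 2.7-fold lower number from compound 3 to compound 4 (0.43 log units; beyond the scatter), the same direction as the step on the other core. The two steps cannot be told apart in size: the same change on two cores in this assay, a 3.7-fold lower number (0.57 log units; beyond the scatter) from compound 2 to compound 1 and a 2.7-fold lower number (0.43 log units; beyond the scatter) from compound 3 to compound 4, 1.4-fold (0.14 log units) apart, within the scatter of two such steps. This shows that the change carried over between these two cores in this assay, but it does not show that it would carry to any other core or to another kind of assay, and the numbers alone do not explain the step.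

The compounds shown leave open how a methylamino group or a cyclic amine such as morpholine would compare at this place on either core. They also leave open what a longer chain between the carbonyl and the amine would do, or a hydroxyl group in place of the amine.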